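Urea to amide on a shared pyrazole-bearing scaffold

The source may report more compounds than this note shows. Statements on the series, on what has been measured and on what is new or still open speak of the compounds shown alone.

Measured so far:
Compound 1 `O=C(Nc1cccc(-n2cc(-c3ccncc3)c(-c3cc(O)cc(Cl)c3)n2)c1)Nc1ccc(Cl)c(C(F)(F)F)c1`: -88%
Compound 2 `COc1cc(Cl)cc(-c2nn(-c3cccc(NC(=O)Nc4ccc(Cl)c(C(F)(F)F)c4)c3)cc2-c2ccncc2)c1`: -75%
Compound 3 `COc1cc(Cl)cc(-c2nn(-c3cccc(NC(=O)Nc4cc(C(F)(F)F)cc(C(F)(F)F)c4)c3)cc2-c2ccncc2)c1`: -70%

In a functional assay on HCC 2998 cells (Homo sapiens) for inhibition, read by sulforhodamine B assay, with a stated time of 48 h, tested at 100 uM (a higher number here means a weaker effect of the compound at the concentration tested, a lower number a stronger effect), compound 2 gives -75%, the second highest of the three numbers; compound 3 lies within the scatter of it, while compound 1 lies beyond the scatter, as the step of a number 13 percentage points higher from compound 1 to compound 2 (beyond the scatter) shows. Compound 4 `COc1cc(Cl)cc(-c2nn(-c3cccc(NC(=O)c4cccc(C(F)(F)F)c4)c3)cc2-c2ccncc2)c1` differs from compound 2 by 3-(trifluoromethyl)phenyl in place of (4-chloro-3-(trifluoromethyl)phenyl)amino on a carbonyl carbon. For the measured compounds named here, no measured step touches this part of the molecule; the only step recorded, from compound 1 to compound 2, concerns the other end. The expectation for compound 4 therefore rests on the shared core alone, and a weaker effect, a higher number, is expected, with a wide range: -45% (-85% to 5%), a step of a number 30 percentage points higher from compound 2 to compound 4 (beyond the scatter).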

Compound 4, a percentage reported as activity, at one concentration (the size of the read-out at that concentration, not a potency): 15%
Compound 4: the middle estimate sits 60 percentage points below what was measured; measured number outside the range, above it.
By their numbers in this assay, from the lowest: compound 1; then compounds 2 and 3 (each within the scatter of the next); then compound 4.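

In this assay, putting 3-(trifluoromethyl)phenyl in place of (4-chloro-3-(trifluoromethyl)phenyl)amino on the carbonyl carbon gives a number 90 percentage points higher from compound 2 to compound 4 (beyond the scatter), so this position weighs far more than the oxygen substituent at the other end, which gave a number 13 percentage points higher from compound 1 to compound 2 (beyond the scatter). The change turns the urea into an amide and also loses the chlorine, so this single step cannot separate the two. Nothing available explains the size of the step.

From the compounds shown here alone, whether the urea nitrogen or the chlorine matters more remains open. So does the effect of a piperazine or a carboxylic acid on that carbonyl carbon.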